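Adding a Second Chloro Group to a Purine Cytotoxin

The source may report more compounds than this note shows. Statements on the series, on what has been measured and on what is new or still open speak of the compounds shown alone.

This set of compounds shares a fused bicyclic core carrying a benzyl group that itself bears a chloromethyl group. Compound 1 `ClCc1cccc(Cn2cnc3nc(Cl)nc(Cl)c32)c1` has two chloro groups on the core and is a moderately strong growth inhibitor: in a functional assay on CCRF-CEM cells (Homo sapiens) for cytotoxicity, read by sulforhodamine B assay, with a stated time of 48 h (on this read-out lower numbers stand for stronger inhibition of growth and higher numbers for weaker inhibition of growth), compound 1 gives 1380 nM. Compound 2 `Nc1nc(Cl)c2ncn(Cc3cccc(CCl)c3)c2n1` replaces one of those chloro groups with an amino group; in this assay compound 2 gives 3020 nM, weaker than compound 1 by a margin that lies beyond the usual scatter.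

Among the measured compounds shown here, compound 3 `ClCc1ccc(Cn2cnc3ncnc(Cl)c32)cc1` carries only a single chloro group on the core, and in this assay compound 3 gives "not determined" (no result reported), so compound 3 stands without a number. Compound 4 `ClCc1ccc(Cn2cnc3nc(Cl)nc(Cl)c32)cc1` is the next step: chloro in place of hydrogen on an aromatic carbon. For the measured compounds named here, no measured pair shows what this exact change does on its own, so the size of the step in this assay cannot be read from the data; the closest guide is that compound 1 carries the same pair of chloro groups on its core and inhibits growth in the micromolar range. Compound 4 is therefore expected to land near 1500 nM, with a plausible range from 500 nM to 5000 nM.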

Compound 4, concentration for 50% growth inhibition: 14800 nM
The estimate for compound 4 lay 9.9-fold (0.99 log units) below the measured number; measured number above the stated range.
By their numbers in this assay, from the lowest: compound 1; then compound 2; then compound 4.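

Among the compounds shown here, compound 3 has no number in this assay, so no step from it to compound 4 can be read. The compounds shown leave open what the entering chloro group does on its own to growth inhibition. Nothing available here offers an explanation for the value of compound 4.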